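Cyano in Place of Fluoro on the Sulfonyl Aryl

The source may hold more compounds than are shown below. What is called first, only, known or untested is meant among the compounds shown, and "the series" means these compounds.

The measured compounds:
compound 1, `COc1ccc(-c2c(S(=O)(=O)c3cccc(C#N)c3)cnc3cc(F)ccc23)cc1`, 0.92 mL/min
compound 2, `O=S(=O)(c1cc(Cl)cc(Cl)c1)c1cnc2cc(F)ccc2c1-c1cccc(F)c1`, 0.41 mL/min
compound 3, `O=S(=O)(c1cccc(F)c1)c1cnc2cc(F)ccc2c1-c1cccc(F)c1`, 0.24 mL/min

In an ADME assay on microsomes from liver (Homo sapiens) for metabolic stability, tested at 2.5 uM (a lower number here means slower removal, a higher number faster removal of the compound), compound 3 gives 0.24 mL/min, compound 2 gives 0.41 mL/min, and compound 1 gives 0.92 mL/min. Compound 3 and compound 2 cannot be told apart, since a 1.7-fold lower number from compound 2 to compound 3 (0.23 log units; within the scatter), whereas compound 1 stands beyond the scatter above both of them. Within the data shown here, compound 3 carries a 3-fluorophenyl on the sulfonyl sulfur; compound 1 carries a 3-cyanophenyl there but also a different aryl group on the shared core, so the two values show a gap but no single-point step can be drawn between them.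

Compound 4, `N#Cc1cccc(S(=O)(=O)c2cnc3cc(F)ccc3c2-c2cccc(F)c2)c1`, has not yet been measured in this assay. It differs from compound 3 in one place: cyano in place of fluoro on an aromatic carbon. Among the measured compounds shown here, the only step that bears on this change is the one on the same sulfonyl aryl, where a 1.7-fold lower number from compound 2 to compound 3 (0.23 log units; within the scatter), a change that stayed within the scatter. For the measured compounds named here, the direction for compound 4 is therefore taken from compound 1, whose 0.92 mL/min is the one number seen with a 3-cyanophenyl on the sulfonyl sulfur, while the size remains uncertain because that compound differs in two places.

Compound 4 is therefore expected to give about 0.35 mL/min, within 0.15 mL/min to 0.8 mL/min, which is a 1.5-fold higher number from compound 3 to compound 4 (0.16 log units; within the scatter) and is expected to stay inside the scatter.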

Compound 4, intrinsic clearance in a liver preparation (reported as CLH), per the amount of preparation that the assay uses: 0.78 mL/min
Compound 4: the middle estimate sits 2.2-fold (0.35 log units) below what was measured; low and high end bracket the measured number.
By their numbers in this assay, from the lowest: compounds 3, 2, 4 and 1 (each within the scatter of the next, the first and the last beyond it).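

In this assay, among these compounds, the exchange of fluoro for cyano gives the one single-place step on the sulfonyl aryl that lies beyond the scatter (a 3.3-fold higher number from compound 3 to compound 4 (0.51 log units; beyond the scatter)), whereas the exchange of 3,5-dichlorophenyl for 3-fluorophenyl on the sulfonyl sulfur stayed inside it. The 3-cyanophenyl compound cannot be told apart from the 3,5-dichlorophenyl compound (a 1.9-fold higher number from compound 2 to compound 4 (0.28 log units; within the scatter)), and it also cannot be told apart from its partner carrying 4-methoxyphenyl in place of 3-fluorophenyl on the shared core (a 1.2-fold lower number from compound 1 to compound 4 (0.07 log units; within the scatter)), so among these compounds that aryl exchange leaves the number unresolved while the exchange on the sulfonyl aryl does not. No measurement at hand offers an explanation for the step from fluoro to cyano.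

What the compounds shown leave open is how another group at this place on the sulfonyl aryl, such as an amine, a carboxylic acid or a longer alkyl chain, would read in this assay against fluoro and cyano. They also leave open whether the step from fluoro to cyano would hold with 4-methoxyphenyl on the shared core in place of 3-fluorophenyl.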